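A few compounds are considered here, and "the series" means these few. Any claim that something is new, unique, unknown or untested is made for them only; others in the source may bear on it.

Measured compounds:
- compound 1 `Cn1c(-c2cccnc2)nc2ccc(F)cc21`, 677 nM
- compound 2 `Fc1cccc2nc(-c3cccnc3)n(C3CC3)c12`, > 10000 nM

The study was read in an assay on V79 cells for inhibition of cytochrome P450 11B1, mitochondrial (Homo sapiens), read by HTRF, with a stated time of 1 h; on this read-out higher numbers stand for weaker inhibition and lower numbers for stronger inhibition. In this assay, going by the values given here, compound 1 gives 677 nM, the only plain number in the set. Among the compounds with values here, the one other value shown is a limit. Compound 2 reaches only the limit of this assay, > 10000 nM, so its two values with compound 1 show a measurable number against a limit and nothing finer than that, as stated in the limit of > 10000 nM in this assay, at which 1 of the 2 values shown sits.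

Compound 3 `CC(C)(C)n1c(-c2cccnc2)nc2ccc(F)cc21` has not yet been measured. It differs from compound 1 by tert-butyl in place of methyl on an aromatic nitrogen. Within the data shown here, no step between two measured compounds isolates this change, so any expectation rests on compound 1 alone. The estimate here is that compound 3 loses activity beyond the usual scatter, with a step of a 4.4-fold higher number from compound 1 to compound 3 (0.65 log units; beyond the scatter) expected for this assay. The value expected for compound 3 is 3000 nM, within a range from 700 nM to 12000 nM, and a real chance remains that only a limit is reported.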

Compound 3, half-maximal inhibitory concentration: > 10000 nM
Compound 3: no number, only a limit; the forecaster's own chance of this, stated with the estimate: 30%; middle value at least 3.3-fold (0.52 log units) from the limit.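

In this assay compound 3 gives > 10000 nM, which is a limit and not a number. Placing tert-butyl in place of methyl on this aromatic nitrogen gives an at least 14-fold higher number from compound 1 to compound 3 (1.16 log units; beyond the scatter), the first step shown that isolates a change at this position, and it shows that the methyl of compound 1 cannot be exchanged for tert-butyl here without a large loss of inhibition. The full size of this loss cannot be read, because the value for compound 3 stops at a limit and the set offers little resolution at the weak end: the limit of > 10000 nM in this assay, at which 2 of the 3 values shown sit.

The compounds shown leave open how the number moves with other groups on this nitrogen, such as a plain hydrogen, ethyl or isopropyl, so a single pair cannot say whether the loss sets in gradually or only with tert-butyl. They also leave open whether a longer chain ending in an amine or a carboxylic acid would be tolerated at this position, and whether the same step would appear on any other target.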